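Swapping the aryl group on the amine of compound 2

The compounds below may be only part of what the source reports. "The series", "measured", "known", "first", "only" and "open" are said of these compounds alone.

Compound 1, `Fc1ccc(NCn2nc(-c3ccc4c(c3)OCCO4)oc2=S)cc1`, gives 6480 nM in a functional assay, with a stated time of 6 min; on this read-out lower numbers stand for stronger inhibition and higher numbers for weaker inhibition.
Compound 2, `S=c1oc(-c2ccc3c(c2)OCCO3)nn1CNc1ccc(Br)cc1Br`, gives 6410 nM in this assay.

Within the data shown here, compound 2 shows the lower of the two numbers, but the only measured step, a 1.0-fold lower number from compound 1 to compound 2 (0.00 log units; within the scatter), lies within the scatter, so the two compounds cannot be told apart on this read-out. Compound 3, `O=[N+]([O-])c1cccc(NCn2nc(-c3ccc4c(c3)OCCO4)oc2=S)c1`, has not been measured yet. It differs from compound 2 in one place: 3-nitrophenyl in place of 2,4-dibromophenyl on an amine nitrogen. Among the measured compounds shown here, the one step that bears on this change is the earlier swap of the aryl group on the same amine nitrogen, which produced no movement beyond the scatter. With no other evidence, no step beyond the scatter is expected for this second swap either. For compound 3 the expected step is a 1.0-fold higher number from compound 2 to compound 3 (0.01 log units; within the scatter). Compound 3 is therefore estimated at 6500 nM, with a range from 2500 nM to 17000 nM.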

Compound 3, half-maximal inhibitory concentration: 8870 nM
Beside the measured number, compound 3's estimate is 1.4-fold (0.14 log units) below it, within the range that was stated.
By their numbers in this assay, from the lowest: compounds 2, 1 and 3 (each within the scatter of the next).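

Replacing 2,4-dibromophenyl on the amine nitrogen with 3-nitrophenyl is a larger change in kind than the earlier swap. The new group has hydrogen-bond acceptors and the group it replaces has none. Even so, this assay gives a 1.4-fold higher number from compound 2 to compound 3 (0.14 log units; within the scatter) and a 1.4-fold higher number from compound 1 to compound 3 (0.14 log units; within the scatter), so all three aryl groups on this nitrogen remain within the scatter of one another. No measurement at hand offers an explanation for this flat result.

Going by these compounds, what remains open is whether a change of another kind on this amine nitrogen, such as a pyridine ring, a cyclohexyl group or a phenyl ring carrying a carboxylic acid, would move the number beyond the scatter. The compounds shown also leave open whether changes to the shared core matter more than changes at this position.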